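A Bromine Added to the Amide-Bearing Ring

A few compounds are considered here, and "the series" means these few. Any claim that something is new, unique, unknown or untested is made for them only; others in the source may bear on it.

Three compounds share one core and differ only in the ring that carries the amide. Compound 1 `Cc1ccc(NC(=O)c2cccc(OCCCCn3ccnc3)c2)cc1Nc1nccc(-c2cccnc2)n1`, compound 2 `Cc1ccc(NC(=O)c2ccc(OCCCCn3ccnc3)c(Br)c2)cc1Nc1nccc(-c2cccnc2)n1` and compound 3 `Cc1ccc(NC(=O)c2ccc(OCCCCn3ccnc3)cc2)cc1Nc1nccc(-c2cccnc2)n1` were tested in a functional assay on K-562R cells (Homo sapiens) for cytotoxicity, read by XTT assay, with a stated time of 24 h; a higher number here means a weaker inhibitor, a lower number a stronger inhibitor. In this assay compound 1 gives 63400 nM, compound 2 gives 31800 nM and compound 3 gives 99400 nM. The difference between the cores of compound 1 and compound 3 is not broken down here. From compound 3 to compound 2 the change is bromo in place of hydrogen on an aromatic carbon, and it gave a 3.1-fold lower number from compound 3 to compound 2 (0.49 log units; beyond the scatter). Compound 4 `Cc1ccc(NC(=O)c2cc(Br)cc(OCCCCn3ccnc3)c2)cc1Nc1nccc(-c2cccnc2)n1` is still unmeasured. From compound 1 to compound 4 the change is bromo in place of hydrogen on an aromatic carbon; this is the same kind of change, though here the bromo sits meta to the 4-(1H-imidazol-1-yl)butoxy group rather than ortho to it. Within the data shown here, the step from compound 1 to compound 4 in this assay is expected to be a 2.0-fold lower number from compound 1 to compound 4 (0.30 log units; within the scatter), resting on the single earlier step of a 3.1-fold lower number from compound 3 to compound 2 (0.49 log units; beyond the scatter). Compound 4 is therefore estimated at 32000 nM, with a likely range from 12000 nM to 85000 nM.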

Compound 4, half-maximal inhibitory concentration: 19100 nM
Beside the measured number, compound 4's estimate is 1.7-fold (0.22 log units) above it; measured number inside the range.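

In this assay bromo in place of hydrogen on an aromatic carbon gave a 3.3-fold lower number from compound 1 to compound 4 (0.52 log units; beyond the scatter) and so lowered the number on the core of compound 1 as well. Set beside the earlier step, the size of the change held from one core to the other: the same change on two cores in this assay, a 3.1-fold lower number (0.49 log units; beyond the scatter) from compound 3 to compound 2 and a 3.3-fold lower number (0.52 log units; beyond the scatter) from compound 1 to compound 4, 1.1-fold (0.03 log units) apart, within the scatter of two such steps. Among these compounds, this rests on only two pairs in a single cell assay, and it shows neither why the number falls nor that the change would carry to any further core.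

The compounds shown leave open whether a chlorine or a methyl group would give a similar step in place of the bromo. They also leave open whether the step would survive a shorter or longer chain than the 4-(1H-imidazol-1-yl)butoxy group.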